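Changing the Aryl Group on the Amide Nitrogen

A few compounds are considered here, and "the series" means these few. Any claim that something is new, unique, unknown or untested is made for them only; others in the source may bear on it.

compound 1, `Cn1cc(C2=C(c3nn(CCCN4CCCCC4)c4ncccc34)C(=O)N(c3ccc(Cl)cc3)C2=O)c2ccccc21`: > 100000 nM
compound 2, `COc1ccc(N2C(=O)C(c3cn(C)c4ccccc34)=C(c3nn(CCCN4CCCCC4)c4ncccc34)C2=O)cc1`: 1740 nM

In a functional assay on SMMC-7721 cells (Homo sapiens) for antiproliferative activity, read by MTT assay, with a stated time of 48 h (a lower number here means a stronger inhibitor, a higher number a weaker inhibitor), compound 1 gives only a limit, > 100000 nM, not a number. Compound 2 gives 1740 nM, the only number shown here. Going by the values given here, the single measured step, an at least 57-fold lower number from compound 1 to compound 2 (1.75 log units; beyond the scatter), concerns the same aryl group that compound 3, `Cn1cc(C2=C(c3nn(CCCN4CCCCC4)c4ncccc34)C(=O)N(c3cccc4ccccc34)C2=O)c2ccccc21`, now alters: naphthalen-1-yl in place of 4-methoxyphenyl on an amide-type nitrogen in a ring. That step shows this group can move the result a long way, yet it gives no guide to the direction for a second aromatic ring. Compound 3 is therefore expected at 5000 nM, somewhere between 1000 nM and 50000 nM, a step of a 2.9-fold higher number from compound 2 to compound 3 (0.46 log units; beyond the scatter) held with wide uncertainty.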

Compound 3, half-maximal inhibitory concentration: 220 nM
Compound 3: the middle estimate sits 23-fold (1.36 log units) above what was measured; the whole stated range lies above it.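

Compound 3 shows that this position on the amide-type nitrogen accepts naphthalen-1-yl, which has 2 six-membered aromatic rings and 0 hydrogen-bond acceptors, with a 7.9-fold lower number from compound 2 to compound 3 (0.90 log units; beyond the scatter) in this assay. The same group, in place of 4-chlorophenyl, gives an at least 450-fold lower number from compound 1 to compound 3 (2.65 log units; beyond the scatter). Compound 1 gives only a limit, so that step has no exact size: the limit of > 100000 nM in this assay, at which 1 of the 3 values shown sits.

On these data alone, it remains open whether the second ring itself matters or how it is attached, which naphthalen-2-yl could test. An amine or carboxylic acid on the aromatic ring also remains untested among the compounds shown.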